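A few compounds are considered here, and "the series" means these few. Any claim that something is new, unique, unknown or untested is made for them only; others in the source may bear on it.

Compound 1 `C/N=c1\c(O)c(O)\c1=N/Cc1ccc(C#N)cc1` belongs to a small set tested in a functional assay for inhibition, with Rattus norvegicus as the target; a higher number here means a weaker inhibitor, a lower number a stronger inhibitor. In this assay compound 1 gives only the limit of the assay, > 30000 nM, so no number stands for it. Compound 2 `CN(C)c1c(NCc2ccc(C#N)cc2)c(=O)c1=O` carries the same nitrile-bearing arm as compound 1. In this assay compound 2 likewise gives only the limit, > 30000 nM. For the measured compounds named here, both measured values thus sit at the limit of > 30000 nM in this assay, at which 2 of the 2 values shown sit, and no step between measured compounds can be stated. Compound 3 `CCC(C)(C)/N=c1\c(O)c(O)\c1=N/Cc1ccc(C#N)cc1` has not yet been measured in this assay. It differs from compound 1 by 1,1-dimethylpropyl in place of methyl on a double-bonded nitrogen. With both measured compounds at the limit, nothing measured indicates which way 1,1-dimethylpropyl on that nitrogen moves the read-out. The change is therefore expected to give a number no higher from compound 1 to compound 3 (the limit leaves the size open), that is none beyond the scatter. For compound 3 the half-maximal inhibitory concentration is estimated at 30000 nM, within a range of 8000 nM to 100000 nM, a limit-only result remaining the most likely outcome.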

Compound 3, half-maximal inhibitory concentration: 1100 nM
Compound 3: middle estimate off by 27-fold (1.44 log units), on the high side; measured number below the stated range.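

In this assay, 1,1-dimethylpropyl in place of methyl on a double-bonded nitrogen gives an at least 27-fold lower number from compound 1 to compound 3 (1.43 log units; beyond the scatter), so the substituent at this place can bring the read-out into the measurable range. Compound 3, at 1100 nM, is the only compound shown that has a number rather than a limit. The size of the step is a floor and not a measured difference, since its starting point is a limit: the limit of > 30000 nM in this assay, at which 2 of the 3 values shown sit.

With only methyl and 1,1-dimethylpropyl shown on this nitrogen, the read-out cannot be tied to chain length or to branching; ethyl, tert-butyl and a straight pentyl chain would separate the two. Also open, as far as these compounds go, is how this place responds to a ring such as cyclohexyl or to a chain ending in an amine or a carboxylic acid.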